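This account rests on a few compounds, and the source may have more. Where it says the series, first, only, none or still open, it means among the compounds named here.

In a functional assay on CHO cells for antagonist activity at prostaglandin E2 receptor EP3 subtype (Homo sapiens), read by cAMP accumulation (on this read-out higher numbers stand for weaker inhibition and lower numbers for stronger inhibition), compound 2 `CC(C)C(CC(N)=O)c1ccc(-c2ccc3cccc(F)c3c2)[nH]c1=O` gives 53 nM, the higher of the two numbers recorded so far. For the measured compounds named here, compound 1 `CC(C)C(c1nnc[nH]1)c1ccc(-c2ccc3cccc(F)c3c2)[nH]c1=O` gives 21 nM, and the step of a 2.5-fold higher number from compound 1 to compound 2 (0.40 log units; beyond the scatter) is the only measured change that bears on what follows. Compound 3 `Cc1c[nH]c(C(c2ccc(-c3ccc4cccc(F)c4c3)[nH]c2=O)C(C)C)n1` carries 4-methyl-1H-imidazol-2-yl in place of carbamoylmethyl on a saturated chain carbon bound to an aromatic carbon and a saturated chain carbon. Because compound 1 also bears a five-membered aromatic ring with two hetero atoms on that same carbon and the step of a 2.5-fold higher number from compound 1 to compound 2 (0.40 log units; beyond the scatter) raised the number, a reversal of roughly that size is expected here. Compound 3 is therefore estimated to give 25 nM, in a range from 10 nM to 65 nM, an expected step of a 2.1-fold lower number from compound 2 to compound 3 (0.33 log units; beyond the scatter).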

Compound 3, half-maximal inhibitory concentration: 36 nM
Beside the measured number, compound 3's estimate is 1.4-fold (0.16 log units) below it; low and high end bracket the measured number.
By their numbers in this assay, from the lowest: compounds 1, 3 and 2 (each within the scatter of the next, the first and the last beyond it).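

On this saturated chain carbon, 4-methyl-1H-imidazol-2-yl can replace carbamoylmethyl (a 1.5-fold lower number from compound 2 to compound 3 (0.17 log units; within the scatter)) or 4H-1,2,4-triazol-3-yl (a 1.7-fold higher number from compound 1 to compound 3 (0.23 log units; within the scatter)), and neither change moves the number beyond the scatter. Compound 3 thus lies within the scatter of both compound 1 and compound 2, although those two differ beyond it, so it does not settle whether the ring compounds form a separate group from the amide. Nothing available explains these numbers.

Still open, from the compounds shown here alone, is how an amine or a carboxylic acid on this carbon would compare, and what the methyl contributes compared with a plain imidazol-2-yl ring.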